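Aryl-amide series: sulfonamide nitrogen extension with a thiazolyl group

The source may report more compounds than this note shows. Statements on the series, on what has been measured and on what is new or still open speak of the compounds shown alone.

Measured so far in an in vitro assay on Sf21 cells for inhibition of high affinity 3',5'-cyclic-AMP phosphodiesterase 7A (Homo sapiens), read by scintillation proximity assay, with a stated time of 30 min; on this read-out lower numbers stand for stronger inhibition and higher numbers for weaker inhibition:
compound 1 `Nc1ccc(NC(=O)c2cn(Cc3c(F)cccc3F)c3ccc(=O)[nH]c3c2=O)cc1` gives 104 nM
compound 2 `CC(=O)Nc1ccc(NC(=O)c2cn(Cc3c(F)cccc3F)c3ccc(=O)[nH]c3c2=O)cc1` gives 24 nM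
compound 3 `NS(=O)(=O)c1ccc(NC(=O)c2cn(Cc3c(F)cccc3F)c3ccc(=O)[nH]c3c2=O)cc1` gives 34 nM

Compound 3 stands second highest of the three numbers; its nearest neighbour is compound 2, a 1.4-fold higher number from compound 2 to compound 3 (0.15 log units; within the scatter), and its furthest compound 1, a 3.1-fold lower number from compound 1 to compound 3 (0.49 log units; beyond the scatter).

Compound 4 `O=C(Nc1ccc(S(=O)(=O)Nc2nccs2)cc1)c1cn(Cc2c(F)cccc2F)c2ccc(=O)[nH]c2c1=O` carries 1,3-thiazol-2-yl in place of hydrogen on a sulfonamide nitrogen. Within the data shown here, no measured step alters this nitrogen. Among the measured compounds shown here, the only step that adds a group onto a nitrogen is a 4.3-fold lower number from compound 1 to compound 2 (0.64 log units; beyond the scatter), modest and on a different nitrogen; the steps at the substituent itself, a 3.1-fold lower number from compound 1 to compound 3 (0.49 log units; beyond the scatter) and a 1.4-fold higher number from compound 2 to compound 3 (0.15 log units; within the scatter), change the group rather than extend it. Little direct guidance exists, so a step within the scatter is expected, a 1.1-fold lower number from compound 3 to compound 4 (0.05 log units; within the scatter).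

For compound 4 the expected value in this assay is 30 nM, range 12 nM to 90 nM.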

Compound 4, half-maximal inhibitory concentration: 25 nM
For compound 4 the middle estimate is 1.2-fold (0.08 log units) above the measured one, within the range that was stated.
By their numbers in this assay, from the lowest: compounds 2, 4 and 3 (each within the scatter of the next); then compound 1.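

In this assay, the sulfonamide nitrogen accepts the 1,3-thiazol-2-yl group with no change beyond the scatter (a 1.4-fold lower number from compound 3 to compound 4 (0.13 log units; within the scatter)). The larger (1,3-thiazol-2-yl)sulfamoyl substituent also stays level with acetamido (a 1.0-fold higher number from compound 2 to compound 4 (0.02 log units; within the scatter)) and retains the gain over amino (a 4.2-fold lower number from compound 1 to compound 4 (0.62 log units; beyond the scatter)). No data at hand account for this result.

On these data alone, whether a methyl group or a longer chain ending in an amine on this nitrogen would give a similar number remains open. So does whether a phenyl ring could replace the 1,3-thiazol-2-yl group.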